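A few compounds are considered here, and "the series" means these few. Any claim that something is new, unique, unknown or untested is made for them only; others in the source may bear on it.

Three compounds built on one shared core have been run in a functional assay on MCF7 cells (Homo sapiens), tested at 7.5 uM; on this read-out higher numbers stand for a weaker effect at the one concentration tested and lower numbers for a stronger effect. In this assay compound 1 `C=CCOc1c(C)c(C)c2c(c1C)CCC(C)(COc1ccc(/C=C3\SC(=O)NC3=O)cc1)O2` gives 2%. Compound 2 `C=CCOc1c(C)c(C)c2c(c1C)CCC(C)(COc1cccc(/C=C3\SC(=O)NC3=O)c1)O2` gives 75%. Compound 3 `CC(C)=CCOc1c(C)c(C)c2c(c1C)CCC(C)(COc1ccc(/C=C3\SC(=O)NC3=O)cc1F)O2` gives 64%, the second highest of the three numbers: the nearest number belongs to compound 2, which stands higher by a gap beyond the usual scatter, and the furthest belongs to compound 1, which lies far lower, again beyond the scatter.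

Compound 4 `CC(C)=CCOc1c(C)c(C)c2c(c1C)CCC(C)(COc1ccc(/C=C3\SC(=O)NC3=O)cc1-c1ccc(F)cc1)O2` has not yet been measured. It differs from compound 3 in a single place: 4-fluorophenyl in place of fluoro on an aromatic carbon. Among the measured compounds shown here, no pair of measured compounds shows this same change, so there is no step to read it against. With nothing to rest on, the expected step is a number 2 percentage points lower from compound 3 to compound 4 (within the scatter), which is a change not beyond the scatter. On that basis compound 4 is estimated to give about 62% in this assay, within a range from 35% to 90%.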

Compound 4, a percentage reported as activity, at one concentration (the size of the read-out at that concentration, not a potency): 85%
For compound 4 the middle estimate is 23 percentage points below the measured one; the range from low to high includes it.
By their numbers in this assay, from the lowest: compound 1; then compound 3; then compounds 2 and 4 (each within the scatter of the next).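

In this assay, replacing the fluoro (1 heavy atom) with 4-fluorophenyl (7 heavy atoms, one six-membered aromatic ring) gives a number 21 percentage points higher from compound 3 to compound 4 (beyond the scatter), so this change goes with a weaker effect at the single concentration tested. Among the compounds shown here, this is the first step that can be read at this place, an aromatic carbon ortho to a large group, as no two earlier compounds differed in one place only. Nothing measured here bears on what lies behind the rise.

A single pair cannot show whether the added ring or the fluorine on it matters more, and a plain phenyl at this carbon would separate the two. On these data alone, how an amine or a short carbon chain would read at the same place also remains open.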